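Compound 3 Anchors a Step to a Ketone

The source may hold more compounds than are shown below. What is called first, only, known or untested is meant among the compounds shown, and "the series" means these compounds.

Compound 1 `COc1cc(-c2nnc(SC)n2-c2ccc(N(C)C)cc2)cc(OC)c1OC`: > 60000 nM (a limit of the assay)
Compound 2 `COc1cc(-c2nnc(SCc3ccc(C)cc3)n2-c2ccc(N(C)C)cc2)cc(OC)c1OC`: > 60000 nM (a limit of the assay)
Compound 3 `COc1cc(-c2nnc(SCc3ccc(F)cc3)n2-c2ccc(N(C)C)cc2)cc(OC)c1OC`: 26400 nM

In a functional assay on HepG2 cells (Homo sapiens) for inhibition, read by MTT assay, with a stated time of 48 h (on this read-out higher numbers stand for weaker inhibition and lower numbers for stronger inhibition), compound 3 gives 26400 nM, the only true number shown. Compound 1 and compound 2 stand at the limit of > 60000 nM in this assay, at which 2 of the 3 values shown sit.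

Compound 4 `COc1ccc(C(=O)CSc2nnc(-c3cc(OC)c(OC)c(OC)c3)n2-c2ccc(N(C)C)cc2)cc1` differs from compound 3 by (4-methoxyphenyl)carbonyl in place of 4-fluorophenyl on a saturated chain carbon bound to a sulfur. For the measured compounds named here, three measured steps bear on this place: an at least 2.2-fold lower number from compound 1 to compound 3 (0.35 log units; beyond the scatter), an at least 2.2-fold lower number from compound 2 to compound 3 (0.35 log units; beyond the scatter), and a step that the two limits leave unreadable from compound 1 to compound 2. None of them involves a carbonyl, so no direction can be read from them, and no change beyond the scatter is expected in this assay. The expected step is a 1.1-fold lower number from compound 3 to compound 4 (0.02 log units; within the scatter). For compound 4 the estimate is 25000 nM, with an expected range from 7000 nM to 60000 nM.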

Compound 4, half-maximal inhibitory concentration: 18800 nM
For compound 4 the middle estimate is 1.3-fold (0.12 log units) above the measured one; the range from low to high includes it.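

In this assay, a carbonyl now stands on the saturated chain carbon bound to a sulfur, and the result is a second true number at this place, with a step that stays within the scatter: a 1.4-fold lower number from compound 3 to compound 4 (0.15 log units; within the scatter). Set against the two weakest-reading compounds, the same group gives an at least 3.1-fold lower number from compound 2 to compound 4 (0.50 log units; beyond the scatter) and an at least 3.1-fold lower number from compound 1 to compound 4 (0.50 log units; beyond the scatter). Both of these steps start from a limit, not a number: the limit of > 60000 nM in this assay, at which 2 of the 4 values shown sit.

The compounds shown do not separate the carbonyl from the methoxy group, which enter together. From the compounds shown here alone, how an amine, a carboxylic acid or a longer chain would read at this place stays open.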